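A few compounds are considered here, and "the series" means these few. Any claim that something is new, unique, unknown or untested is made for them only; others in the source may bear on it.

Measured in a functional assay on HCC 2998 cells (Homo sapiens) for cytotoxicity, read by luminescence and CellTiter-Glo, with a stated time of 72 h; a lower number here means a stronger inhibitor, a higher number a weaker inhibitor:
- compound 1 `O=C1C=CC[C@@H]([C@H](O)[C@H](O[C@@H](c2ccccc2)[C@@H](O)[C@@H]2CC=CC(=O)O2)c2ccccc2)O1` gives 2900 nM
- compound 2 `O=C1C=CC[C@@H]([C@H](O)[C@@H](O[C@H]([C@@H]2CC=CC(=O)O2)[C@@H](O)c2ccccc2)c2ccccc2)O1` gives > 10000 nM

The entry for compound 2 is a limit of the assay, not a number. Among the measured compounds shown here, that leaves compound 1 as the only compound here with a true number (2900 nM), so it is the reference point for what follows.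

Compound 3 `CC(=O)O[C@@H]([C@@H]1CC=CC(=O)O1)[C@H](O[C@@H](c1ccccc1)[C@@H](O)[C@@H]1CC=CC(=O)O1)c1ccccc1` is compound 1 with a single change (acetyl in place of hydrogen on an oxygen on a saturated carbon): acetyl in place of hydrogen on an oxygen on a saturated carbon, which turns hydroxy into acetoxy. For the measured compounds named here, no measured pair here shows what such a change does, so the expectation is loose. The likeliest result in this assay is a step no larger than the scatter, with no firm direction.

The estimated value for compound 3 is (2500 nM), with an expected range from (500 nM) to (10000 nM). This is the expected step (a 1.2-fold lower number from compound 1 to compound 3 (0.06 log units; within the scatter)).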

Compound 3, half-maximal inhibitory concentration: > 10000 nM
Compound 3 gave a limit, no number; the forecaster's own chance of this, stated with the estimate: 20%; at least 4.0-fold (0.60 log units) between middle value and limit.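

In this assay, among the compounds shown here, this is the first single change that can be read, and putting acetyl on this oxygen on a saturated carbon costs activity: an at least 3.4-fold higher number from compound 1 to compound 3 (0.53 log units; beyond the scatter). Compound 3 gives > 10000 nM, which is a limit of the assay and not a number. The step is therefore a minimum, and the true size of the loss cannot be read, since compound 3 sits at the same ceiling as most of the series: the limit of > 10000 nM in this assay, at which 2 of the 3 values shown sit.

Acetyl is the only group shown on this oxygen, so it stays open whether a methyl ether or a benzoyl ester would cost as much as the acetoxy does. Also open, on these data alone, is whether an amine in place of the hydroxy would keep the activity of compound 1.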